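Aryl swap on the shared core: compound 3 to compound 4

A few compounds are considered here, and "the series" means these few. Any claim that something is new, unique, unknown or untested is made for them only; others in the source may bear on it.

Of the compounds shown here, three have been measured. In an in vitro assay on HEK385-7 cells for displacement of a labelled ligand from prostaglandin D2 receptor 2 (Homo sapiens) (a higher number here means a weaker inhibitor, a lower number a stronger inhibitor), compound 1 `COc1ccc(C(c2ccccn2)c2nc(-c3ccc(Cl)cc3)c(CC(=O)O)s2)cc1` gives 61 nM. In this assay compound 2 `O=C(O)Cc1sc(C(c2ccccc2)c2ccccc2)nc1-c1ccccc1` gives 570 nM. Compound 3 `NS(=O)(=O)c1cccc(-c2nc(C(c3ccc(F)cc3)c3ccc(F)cc3)sc2CC(=O)O)c1` gives 140 nM in this assay, which places it second highest of the three numbers: nearest to compound 1, which stands beyond the scatter at the lower side, and furthest from compound 2, which stands beyond the scatter at the higher side. Going by the values given here, no single-change step between measured compounds is available, so the aryl group on the shared core has no measured step to lean on.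

Compound 4 `O=C(O)Cc1sc(C(c2ccc(F)cc2)c2ccc(F)cc2)nc1-c1ccnc(N2CCCC2)c1` is not yet measured. It differs from compound 3 in one place: 2-(pyrrolidin-1-yl)pyridin-4-yl in place of 3-sulfamoylphenyl on an aromatic carbon. Among the compounds with values here, with no measured step of this kind, a step of compound 3 to compound 4 within the scatter, or at most a modest weakening, is expected, and the estimated step is a 1.4-fold higher number from compound 3 to compound 4 (0.15 log units; within the scatter). Compound 4 is accordingly expected to give 200 nM in this assay, with a range from 60 nM to 700 nM.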

Compound 4, half-maximal inhibitory concentration: 230 nM
Compound 4: the middle estimate sits 1.2-fold (0.06 log units) below what was measured, and the stated range covers the measured number.
By their numbers in this assay, from the lowest: compound 1; then compounds 3 and 4 (each within the scatter of the next); then compound 2.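

Going by these compounds alone, this is the first single-place step: in this assay, 2-(pyrrolidin-1-yl)pyridin-4-yl in place of 3-sulfamoylphenyl gives a 1.6-fold higher number from compound 3 to compound 4 (0.22 log units; within the scatter), with the rest of the compound held constant. At this aromatic carbon, next to the ring nitrogen and next to the ring atom bearing the carboxymethyl group, two quite different aryl groups therefore read the same within the scatter, even though the hydrogen-bond donor of the sulfamoyl group is absent from the entering group. Nothing available explains the size of this step.

Going by these compounds, it remains open whether a morpholine or a dimethylamino group in place of the pyrrolidine ring would also stay within the scatter, and what an unsubstituted pyridin-4-yl would give. On these data alone, the carboxymethyl group is common to all four compounds, so the effect of a longer acid chain, such as carboxyethyl, also remains open.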